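The compounds below may be only part of what the source reports. "The series", "measured", "known", "first", "only" and "open" are said of these compounds alone.

Working notes on the series

Compound 1 `Cc1cc(S(=O)(=O)/N=C(\N)n2nccc2-c2ccccc2)c(SCc2ccc(C(F)(F)F)cc2)cc1Cl` carries a 4-(trifluoromethyl)phenyl on the saturated chain carbon bound to sulfur; in an ADME assay on microsomes from liver (Homo sapiens) for metabolic stability, read by LC-MS, using NADPH, tested at 5 uM (a lower number here means that the compound disappears faster, a higher number that the compound lasts longer), compound 1 gives 0.176 h. Compound 2 `Cc1cc(S(=O)(=O)/N=C(\N)n2nccc2-c2ccccc2)c(SCc2ccccc2C)cc1Cl` differs only there, and in this assay compound 2 gives 0.0802 h. For the measured compounds named here, the single measured step, a 2.2-fold lower number from compound 1 to compound 2 (0.34 log units; beyond the scatter), is the only comparison available. Going by the values given here, compound 2 therefore stands at the lower of the two numbers so far, with compound 1 as its only neighbour.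

Compound 3 `Cc1cc(S(=O)(=O)/N=C(\N)n2nccc2-c2ccccc2)c(SCc2cccc(C(F)(F)F)c2)cc1Cl` is the next member. Its change from compound 2 is 3-(trifluoromethyl)phenyl in place of 2-methylphenyl on a saturated chain carbon bound to a sulfur. Among the compounds with values here, the one measured step bears directly on this: it replaced a trifluoromethylphenyl with a methylphenyl and went down by a 2.2-fold lower number from compound 1 to compound 2 (0.34 log units; beyond the scatter). Compound 3 brings a trifluoromethylphenyl back, though as the 3-(trifluoromethyl)phenyl rather than the 4-(trifluoromethyl)phenyl of compound 1, so a move back toward compound 1 is expected, of roughly that size but less certain. For compound 3 the expected step is a 1.9-fold higher number from compound 2 to compound 3 (0.27 log units; within the scatter), an increase in this assay. Compound 3 is thus estimated at 0.15 h, within 0.07 h to 0.32 h.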

Compound 3, half-life: 0.0863 h
The estimate for compound 3 lay 1.7-fold (0.24 log units) above the measured number, within the range that was stated.
By their numbers in this assay, from the lowest: compounds 2 and 3 (each within the scatter of the next); then compound 1.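

Among the groups on the saturated chain carbon bound to a sulfur, the location of the trifluoromethyl on the phenyl ring now counts in this assay: 3-(trifluoromethyl)phenyl in place of 4-(trifluoromethyl)phenyl gives a 2.0-fold lower number from compound 1 to compound 3 (0.31 log units; beyond the scatter), so a trifluoromethylphenyl does not by itself preserve the number seen for compound 1. The exchange of 2-methylphenyl for 3-(trifluoromethyl)phenyl gives a 1.1-fold higher number from compound 2 to compound 3 (0.03 log units; within the scatter), which leaves these two groups indistinguishable here despite their different atoms, and compound 1 is the only one of the three set apart beyond the scatter from both others. No measurement at hand offers an explanation for this pattern.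

The three compounds cannot separate the identity of the substituent from its location on the ring, since a 4-methylphenyl, which would pair directly with compound 1, is not among them. As far as these compounds go, it also remains open how this place responds to groups of a different kind, such as a carboxylic acid or an amine on the phenyl ring, or to a longer chain between the sulfur and the ring.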